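Methoxy added to a quinoxaline sulfone anilide series

The source may hold more compounds than are shown below. What is called first, only, known or untested is meant among the compounds shown, and "the series" means these compounds.

Measured compounds:
- compound 1, `COc1ccc(Nc2nc3ccccc3nc2S(=O)(=O)c2ccccc2)cc1`: 640 nM
- compound 2, `COc1ccc(Nc2nc3ccccc3nc2S(=O)(=O)c2ccc(OC)cc2)cc1`: 1190 nM
- compound 3, `COc1cc(Nc2nc3ccccc3nc2S(=O)(=O)c2ccc(Br)cc2)cc(OC)c1`: 2540 nM

In a functional assay on HL-60 cells (Homo sapiens) for cytotoxicity, read by MTT assay, with a stated time of 72 h (a lower number here means a stronger inhibitor, a higher number a weaker inhibitor), compound 1 gives 640 nM. Compound 2 differs from it by methoxy in place of hydrogen on an aromatic carbon, and the step of a 1.9-fold higher number from compound 1 to compound 2 (0.27 log units; within the scatter) is a small one. Compound 3, in the same assay, gives 2540 nM, the highest of the three numbers; its value lies beyond the scatter from both compound 1 and compound 2. The difference between the cores of compound 1 and compound 3 is not broken down here.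

Compound 4, `COc1cc(Nc2nc3ccccc3nc2S(=O)(=O)c2ccc(Br)cc2)cc(OC)c1OC`, has not yet been measured. It differs from compound 3 by methoxy in place of hydrogen on an aromatic carbon. This is the same kind of change as that from compound 1 to compound 2, but the place is not the same: in compound 4 the new methoxy sits ortho to two methoxy groups (2 heavy atoms each) as well as para to a large group, whereas in compound 2 it is only para to a large group. Among the measured compounds shown here, only one such step is available, and it was within the scatter. On that basis the step from compound 3 to compound 4 is expected to be small, in the same direction, about a 1.5-fold higher number from compound 3 to compound 4 (0.17 log units; within the scatter), with wide uncertainty since the surroundings of the change differ. Compound 4 is therefore estimated to give 3800 nM in this assay, between 1500 nM and 9500 nM.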

Compound 4, half-maximal inhibitory concentration: 1020 nM
Estimate against measurement, compound 4: 3.7-fold (0.57 log units) above; the measured number lies below the stated range.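

In this assay, placing a methoxy on an aromatic carbon in compound 3 gave a 2.5-fold lower number from compound 3 to compound 4 (0.40 log units; beyond the scatter), whereas the earlier step of the same kind was small and ran the other way. In this series, therefore, the size and direction of this change cannot simply be carried from one core to another, as the two cases shown do not agree: the same change on two cores in this assay, a 1.9-fold higher number (0.27 log units; within the scatter) from compound 1 to compound 2 and a 2.5-fold lower number (0.40 log units; beyond the scatter) from compound 3 to compound 4, 4.6-fold (0.67 log units) apart, beyond the scatter of two such steps

This does not show why the two steps part, since the pairs differ both in their cores and in the surroundings of the new methoxy, which in compound 4 is ortho to two methoxy groups as well as para to a large group, whereas in compound 2 it is only para to a large group; two steps cannot separate these differences, and they cannot say how the change would behave on a further core.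

The compounds shown leave open what a hydroxy group, an amine or a carboxylic acid would do in the place the new methoxy holds in compound 4. They also leave open whether an ethoxy group or a longer chain there would follow the step seen with methoxy.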